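The source may report more compounds than this note shows. Statements on the series, on what has been measured and on what is new or still open speak of the compounds shown alone.

Compound 1 `CNC(=O)c1cc(Oc2ccc(C3=NNC(c4ccc(Cl)cc4Cl)C3)cc2)ccn1`: 6930 nM
Compound 2 `CNC(=O)c1cc(Oc2ccc(C3=NNC(c4cccc(Br)c4)C3)cc2)ccn1`: 2840 nM
Compound 3 `CNC(=O)c1cc(Oc2ccc(C3=NNC(c4ccc(OC)cc4)C3)cc2)ccn1`: 13100 nM

In a functional assay on A549 cells (Homo sapiens) for cytotoxicity, read by MTT assay, with a stated time of 72 h (a lower number here means a stronger inhibitor, a higher number a weaker inhibitor), compound 3 gives 13100 nM. That places it at the upper end of this small set, a position it shares with compound 1. The measured steps are a 1.9-fold higher number from compound 1 to compound 3 (0.28 log units; within the scatter) and a 4.6-fold higher number from compound 2 to compound 3 (0.66 log units; beyond the scatter).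

Compound 4 `CNC(=O)c1cc(Oc2ccc(C3=NNC(c4ccc(F)cc4)C3)cc2)ccn1` carries one change from compound 3, fluoro in place of methoxy on an aromatic carbon, para to a large group.

Among the compounds with values here, no measured step makes this exact swap, so the evidence is indirect. The best guide is compound 2, a halogen-bearing compound at 2840 nM. Compound 1, also halogen-bearing, gives 6930 nM and offers little support, since its step to the methoxy compound stays within the scatter.

A modest move to a lower number is therefore expected in this assay, and it may not clear the scatter. The expected change is a 2.0-fold lower number from compound 3 to compound 4 (0.30 log units; within the scatter). For compound 4 the estimate is 6500 nM, with an expected range from 2200 nM to 15000 nM.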

Compound 4, half-maximal inhibitory concentration: 15100 nM
The estimate for compound 4 lay 2.3-fold (0.37 log units) below the measured number; the whole stated range lies below it.
By their numbers in this assay, from the lowest: compound 2; then compounds 1, 3 and 4 (each within the scatter of the next, the first and the last beyond it).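

In this assay, the direct swap of 4-methoxyphenyl to 4-fluorophenyl gives a 1.2-fold higher number from compound 3 to compound 4 (0.06 log units; within the scatter), so this change does not separate the two groups at this position. A halogen alone therefore does not bring the number down, as the other halogen-bearing compounds show: the steps are a 5.3-fold higher number from compound 2 to compound 4 (0.73 log units; beyond the scatter) and a 2.2-fold higher number from compound 1 to compound 4 (0.34 log units; beyond the scatter), and each of them changes both the halogen and where it sits on the ring. Nothing measured here offers a reason for this result.

Still open, from the compounds shown here alone, is whether bromo in place of fluoro, para to a large group, would come close to compound 2, which would separate the effect of the halogen from that of its place. Going by these compounds, it is also open how an amine or a carboxylic acid at this position would read.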